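This account rests on a few compounds, and the source may have more. Where it says the series, first, only, none or still open, it means among the compounds named here.

Among the compounds with values here, in an ADME assay on Caco-2 cells (Homo sapiens) for permeability, read by LC-MS, with a stated time of 2 h (on this read-out higher numbers stand for higher permeability and lower numbers for lower permeability), compound 1 `COc1cc(CN(CC2CC2)C(CC(=O)O)c2ccc(Cl)cc2)ccc1OCCn1c(=O)ccn(C)c1=O` gives 0.8 nm/s and compound 2 `COc1cc(CN(C2CCC2)C(CC(=O)O)c2ccc(Cl)cc2)ccc1OCCn1c(=O)ccn(C)c1=O` gives 1.7 nm/s, so compound 2 holds the higher of the two numbers measured so far. Compound 3 `CCCCN(Cc1ccc(OCCn2c(=O)ccn(C)c2=O)c(OC)c1)C(CC(=O)O)c1ccc(Cl)cc1` keeps the rest of compound 2 and alters one group: butyl in place of cyclobutyl on an amine nitrogen. Within the data shown here, only one measured step bears on this change, cyclobutyl in place of cyclopropylmethyl on the same amine nitrogen, and it is modest, though beyond the scatter: a 2.1-fold higher number from compound 1 to compound 2 (0.33 log units; beyond the scatter). Among the measured compounds shown here, no compound with an open butyl chain at this place has been measured yet, so the direction of the change is uncertain, and a step beyond the scatter is not expected. The estimated change is small: a 1.2-fold lower number from compound 2 to compound 3 (0.08 log units; within the scatter). In this assay, compound 3 is expected at 1.4 nm/s, with an estimated range from 0.6 nm/s to 3.5 nm/s.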

Compound 3, apparent permeability: 1.5 nm/s
The estimate for compound 3 lay 1.1-fold (0.03 log units) below the measured number; low and high end bracket the measured number.
By their numbers in this assay, from the lowest: compounds 1, 3 and 2 (each within the scatter of the next, the first and the last beyond it).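

In this assay, butyl in place of cyclobutyl on the amine nitrogen gives a result within the scatter (a 1.1-fold lower number from compound 2 to compound 3 (0.05 log units; within the scatter)), so with the same 4 heavy atoms on either side, removing the four-membered ring leaves no clear mark on the number at this place. Propyl in place of cyclopropyl on the saturated chain carbon bound to the amine nitrogen also stays within the scatter (a 1.9-fold higher number from compound 1 to compound 3 (0.27 log units; within the scatter)), which means the open butyl chain cannot be told apart from either ring-bearing group, even though those two groups differ from each other beyond the scatter. Nothing available here explains these numbers.

From the compounds shown here alone, how a longer chain such as hexyl, or a chain ending in a hydroxyl or an amine, would read on this nitrogen remains open. So does whether any group at this place can move the number by much more than these small steps.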